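A few compounds are considered here, and "the series" means these few. Any claim that something is new, unique, unknown or untested is made for them only; others in the source may bear on it.

Of the compounds shown here, three sharing one core have been measured. Compound 1 `C=CCOc1cc(OC)c(C(=O)/C=C/c2ccccc2)c(OCC=C)c1` gives 17100 nM in an ADME assay on Vero cells (Chlorocebus sabaeus) for cytotoxicity, read by MTT assay; a higher number here means a weaker inhibitor, a lower number a stronger inhibitor. Compound 2 `C=CCOc1cc(OC)c(C(=O)/C=C/c2cc(OC)c(OC)c(OC)c2)c(OCC=C)c1` gives 40900 nM in this assay, and compound 3 `C=CCOc1cc(OC)c(C(=O)/C=C/c2ccccc2F)c(OCC=C)c1` gives 16300 nM in this assay. Among these three numbers compound 1 holds the second highest. Its nearest neighbour is compound 3, the step of a 1.0-fold lower number from compound 1 to compound 3 (0.02 log units; within the scatter) lying within the scatter; its furthest is compound 2, whose higher number lies beyond the scatter, so compound 2 is a weaker inhibitor of these cells than compound 1.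

Compound 4 `C=CCOc1cc(OC)c(C(=O)/C=C/c2ccc(O)cc2)c(OCC=C)c1` has not yet been measured. It differs from compound 1 in one place: hydroxy in place of hydrogen on an aromatic carbon. Going by the values given here, the only measured step that bears on this change is a 1.0-fold lower number from compound 1 to compound 3 (0.02 log units; within the scatter), which likewise swapped a hydrogen on the same ring for a small group and barely moved the number. Compound 2 carries three methoxy groups on that ring, a larger change that offers only loose guidance. A single hydroxy group is therefore expected to shift the number little, if at all, beyond the scatter, in either direction. The expected step is a 1.2-fold higher number from compound 1 to compound 4 (0.07 log units; within the scatter). For compound 4 the estimate in this assay is 20000 nM, with a range from 9000 nM to 45000 nM.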

Compound 4, half-maximal inhibitory concentration: 76400 nM
Compound 4: the middle estimate sits 3.8-fold (0.58 log units) below what was measured; the whole stated range lies below it.
By their numbers in this assay, from the lowest: compounds 3 and 1 (each within the scatter of the next); then compounds 2 and 4 (each within the scatter of the next).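

Placed on the aromatic ring para to a large group, a single hydroxy gives a 4.5-fold higher number from compound 1 to compound 4 (0.65 log units; beyond the scatter) in this assay and so shows that a one-atom addition at this place can move the number beyond the scatter. Compound 3 alone, with a 1.0-fold lower number from compound 1 to compound 3 (0.02 log units; within the scatter), could not have shown this, since its fluoro group left the number within the scatter of compound 1. The comparison of the two substituted compounds, a 4.7-fold higher number from compound 3 to compound 4 (0.67 log units; beyond the scatter), points the same way, but it alters both the group and its place on the ring, so it cannot say which of the two matters; nothing available explains the rise in the number.

On these data alone, it remains open whether this shift belongs to the hydroxy itself or would also appear with another group at the same place, such as an amine or a carboxylic acid. Also unsettled is whether a hydroxy elsewhere on the ring, or a fluoro at this same place, would give a number like that of compound 4 or one like that of compound 1.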